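Halogenated phenyls on the pyridazinone nitrogen and cytotoxicity

The compounds below may be only part of what the source reports. "The series", "measured", "known", "first", "only" and "open" are said of these compounds alone.

Compound 1 `CNC(=O)c1cc(Oc2ccc(NC(=O)c3nn(-c4ccccc4OC(F)(F)F)c(=O)cc3C)cc2F)ccn1`: in a functional assay on HepG2 cells (Homo sapiens) for cytotoxicity, read by MTT assay, with a stated time of 72 h (on this read-out lower numbers stand for stronger inhibition and higher numbers for weaker inhibition), compound 1 gives only a limit, > 40000 nM.
Compound 2 `Cc1cc(=O)n(-c2ccc(Br)cc2F)nc1C(=O)Nc1ccc(Oc2ncnc3ccsc23)cc1`: compound 2 gives 10600 nM.
Compound 3 `Cc1cc(=O)n(-c2ccccc2OC(F)(F)F)nc1C(=O)Nc1ccc(Oc2ncnc3ccsc23)cc1`: compound 3 gives 25000 nM.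

Within the data shown here, compound 3 stands highest of the two real numbers; the only measured step at this position is a 2.4-fold higher number from compound 2 to compound 3 (0.37 log units; beyond the scatter), where a halogenated phenyl gave way to the trifluoromethoxyphenyl. Compound 4 `Cc1cc(=O)n(-c2ccc(F)c(F)c2)nc1C(=O)Nc1ccc(Oc2ncnc3ccsc23)cc1` returns to a halogenated phenyl: 3,4-difluorophenyl in place of 2-(trifluoromethoxy)phenyl on an aromatic nitrogen. That step bears directly on the change, and a reversal of comparable, modest size back toward the number of compound 2 is expected, with the limit of > 40000 nM in this assay, at which 1 of the 3 values shown sits, showing that very weak activity is the rule in this series. Compound 4 is therefore estimated at 14000 nM (range 6000 nM to 38000 nM), an expected step of a 1.8-fold lower number from compound 3 to compound 4 (0.25 log units; within the scatter).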

Compound 4, half-maximal inhibitory concentration: 9230 nM
Estimate against measurement, compound 4: 1.5-fold (0.18 log units) above; the measured number falls inside the stated range.
By their numbers in this assay, from the lowest: compounds 4 and 2 (each within the scatter of the next); then compound 3. At a limit, above all of these: compound 1.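

The return to a halogenated phenyl undoes the earlier change: in this assay there is a 2.7-fold lower number from compound 3 to compound 4 (0.43 log units; beyond the scatter). The two halogenated phenyls cannot be told apart, with a 1.1-fold lower number from compound 2 to compound 4 (0.06 log units; within the scatter), so among compounds 2, 3 and 4 only the 2-(trifluoromethoxy)phenyl of compound 3 stands apart. Compound 1 gives a limit and not a number: the limit of > 40000 nM in this assay, at which 1 of the 4 values shown sits.

Going by these compounds, whether an amine or a carboxylic acid on this phenyl would shift the number remains open. So does the effect of an unsubstituted phenyl or a simple alkyl chain on the same nitrogen.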